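The source may report more compounds than this note shows. Statements on the series, on what has been measured and on what is new or still open speak of the compounds shown alone.

Compound 1 `CC(=O)c1ccc(Nc2ccnc(SCC(=O)c3ccc(Br)cc3)n2)cc1` is the starting point here. In a functional assay on PC-3 cells (Homo sapiens) for inhibition, read by sulforhodamine B assay, with a stated time of 48 h, tested at 10 uM (a higher number here means more inhibition of growth at the concentration tested, a lower number less inhibition of growth), compound 1 gives 25%, and compound 2 `CC(=O)c1cccc(Nc2ccnc(SCC(=O)c3ccc(-c4ccccc4)cc3)n2)c1` gives 25% in this assay; the two stand level within the usual scatter of this kind of measurement. Compound 3 `CC(=O)c1ccc(Nc2ccnc(SCC(=O)c3ccc(Cl)cc3)n2)cc1` has not yet been measured. It differs from compound 1 by chloro in place of bromo on an aromatic carbon. Among the measured compounds shown here, no measured pair shows this particular swap, so the expected step of no change at the digits printed from compound 1 to compound 3 (within the scatter) is small, in no fixed direction, and not beyond the scatter. Compound 3 is therefore estimated at 25%, with a range from 12% to 40%.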

Compound 3, percent growth inhibition at one concentration: 30%
Compound 3: the middle estimate sits 5 percentage points below what was measured; the range from low to high includes it.
By their numbers in this assay, from the lowest: compounds 1, 2 and 3 (each within the scatter of the next).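

In this assay, among the compounds shown here, the change from 4-bromophenyl to 4-chlorophenyl gives a number 5 percentage points higher from compound 1 to compound 3 (within the scatter) and so offers the first direct comparison at this position. On this single pair, chloro can stand in place of bromo on this ring without a step beyond the scatter. Nothing at hand offers an explanation for this result. Going by these compounds, whether an amine, a carboxylic acid or a longer chain at this position would give a step beyond the scatter remains open. So does whether the same swap would read alike on other compounds.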